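The source may report more compounds than this note shows. Statements on the series, on what has been measured and on what is new or still open speak of the compounds shown alone.

Measured so far in an ADME assay on MT4 cells (Homo sapiens) for cytotoxicity, read by MTT assay; a higher number here means that more compound is tolerated, a lower number that less compound is tolerated:
compound 1, `Cc1cc(C)cc(S(=O)(=O)c2c(C(=O)NCC(=O)NC(C)c3ccccc3)[nH]c3ccc(Cl)cc23)c1`: 29400 nM
compound 2, `Cc1cc(C)cc(S(=O)(=O)c2c(C(=O)NCC(=O)NC(C)c3ccncc3)[nH]c3ccc(Cl)cc23)c1`: 47000 nM
compound 3, `Cc1cc(C)cc(S(=O)(=O)c2c(C(=O)NCC(=O)NCc3ccncn3)[nH]c3ccc(Cl)cc23)c1`: > 48800 nM

The value for compound 3 is a limit of this assay and not a number (the limit of > 48800 nM in this assay, at which 1 of the 3 values shown sits). Of the two numbers, compound 2 has the higher one, but the gap to compound 1 is small, a 1.6-fold higher number from compound 1 to compound 2 (0.20 log units; within the scatter). The step of an at least 1.6-fold higher number from compound 1 to compound 3 (0.22 log units; that floor lies within the scatter) and the step of an at least 1.0-fold higher number from compound 2 to compound 3 (0.01 log units; that floor lies within the scatter) are both floors that lie within the scatter, so the three compounds cannot be ordered on these data.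

Compound 4, `Cc1cc(C)cc(S(=O)(=O)c2c(C(=O)NC(C)C(=O)NC(C)c3ccncc3)[nH]c3ccc(Cl)cc23)c1`, differs from compound 2 by methyl in place of hydrogen on a saturated chain carbon bound to an amide-type nitrogen and a carbonyl carbon. Going by the values given here, none of the measured steps touches this part of the chain; all three concern the group on the amide-type nitrogen at the far end, and all three stayed within the scatter. Among the compounds with values here, there is thus no measured step that argues for a shift in this assay, and a change of one carbon on the chain gives no ground of its own for one. The expected step is a 1.0-fold lower number from compound 2 to compound 4 (0.02 log units; within the scatter), that is, none beyond the scatter. Compound 4 is estimated at 45000 nM, with a range from 22000 nM to 48800 nM, and a real chance that this assay again reports only a limit.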

Compound 4, half-maximal cytotoxic concentration: 21900 nM
Beside the measured number, compound 4's estimate is 2.1-fold (0.31 log units) above it; measured number outside the range, below it.
By their numbers in this assay, from the lowest: compounds 4, 1 and 2 (each within the scatter of the next, the first and the last beyond it). At a limit, above all of these: compound 3.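

In this assay, going by these compounds alone, the saturated chain carbon bound to an amide-type nitrogen and a carbonyl carbon is the first place where a single change gives a step beyond the scatter: methyl in place of hydrogen gives a 2.1-fold lower number from compound 2 to compound 4 (0.33 log units; beyond the scatter). The readable earlier change, on the group at the far amide-type nitrogen, stayed within the scatter, so on present data this chain carbon is the place that responds, although that rests on a single pair and a step of modest size. Nothing in the data shown accounts for the shift.

Open, from the compounds shown here alone, is whether the lower number tracks the size of the group on this carbon, which an ethyl, an isopropyl or a hydroxymethyl group there would test against the methyl of compound 4. Also open, going by these compounds, is whether the same methyl gives a comparable step when the far amide-type nitrogen carries the 1-phenylethyl group of compound 1 or the (pyrimidin-4-yl)methyl group of compound 3, so the step cannot yet be taken as general for the series.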